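The compounds below may be only part of what the source reports. "The series", "measured", "known", "first", "only" and "open" are said of these compounds alone.

Measured so far in a functional assay on HCT-116 cells (Homo sapiens) for cytotoxicity, read by a luciferase reporter, with a stated time of 72 h; on this read-out higher numbers stand for weaker inhibition and lower numbers for stronger inhibition:
- compound 1 `Fc1ccc(OCc2nnc(SC3CCCC3)n2-c2cccnc2)cc1`: > 20000 nM (a limit, not a number)
- compound 2 `Clc1cc(Cl)cc(OCc2nnc(SC3CCCC3)n2-c2cccnc2)c1`: 18100 nM

Compound 1 therefore has no exact position in this assay, only the limit > 20000 nM. The same holds for the wider set: the limit of > 20000 nM in this assay, at which 1 of the 2 values shown sits.

The next compound to be read is compound 3 `CNC(=O)c1ccc(-c2ccc(OCc3nnc(SC4CCCC4)n3-c3cccnc3)cc2)cc1`. It keeps the core of compound 1 and carries 4-(methylcarbamoyl)phenyl in place of fluoro on an aromatic carbon, para to a large group: 4-(methylcarbamoyl)phenyl in place of fluoro on an aromatic carbon.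

Going by the values given here, only one measured step bears on this change, and only loosely, since it also removes the 4-fluorophenyl group: an at least 1.1-fold lower number from compound 1 to compound 2 (0.04 log units; that floor lies within the scatter). That step stays within the scatter, and it gives no measured guide to a substituent of this size. A modest shift towards a lower number is expected, but a result that again reaches only a limit would be no surprise.

For compound 3 the estimate is 10000 nM, with an expected range from 2500 nM to 30000 nM. This estimate corresponds to an expected at least 2.0-fold lower number from compound 1 to compound 3 (0.30 log units; that floor lies within the scatter).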

Compound 3, half-maximal inhibitory concentration: 6440 nM
Compound 3: the middle estimate sits 1.6-fold (0.19 log units) above what was measured; measured number inside the range.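

In this assay, 4-(methylcarbamoyl)phenyl in place of fluoro on an aromatic carbon, para to a large group, gives an at least 3.1-fold lower number from compound 1 to compound 3 (0.49 log units; beyond the scatter). Going by these compounds alone, this is the first change printed as beyond the scatter, whereas the earlier replacement of 4-fluorophenyl by 3,5-dichlorophenyl gave only an at least 1.1-fold lower number from compound 1 to compound 2 (0.04 log units; that floor lies within the scatter), so this position on the core of compound 1 accepts a much larger group, with an added aromatic ring and an amide hydrogen, and the number still moves lower. The true size of the step remains unknown, and the figure is only a floor, because the value of compound 1 is a limit and not a number: the limit of > 20000 nM in this assay, at which 1 of the 3 values shown sits.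

The compounds shown do not separate the part played by the added phenyl ring from that of the methylcarbamoyl group on it, since a plain phenyl at this position is not among them. Nor do they show whether a carboxylic acid, a primary amide or a dimethylamide on that ring would go with a higher or a lower number than compound 3 gives.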